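The source may hold more compounds than are shown below. What is called first, only, known or untested is meant among the compounds shown, and "the series" means these compounds.

In a functional assay on KB cells (Homo sapiens) for cytotoxicity (on this read-out higher numbers stand for an effect only at larger amounts of compound and lower numbers for an effect already at smaller amounts), compound 1 `COC1=C(C)C(=O)/C(=C(O)/C=C/c2ccc(Br)cc2)C(=O)C1(C)C` gives 1.9 ug/mL and compound 2 `CCc1ccc(/C=C/C(O)=C2/C(=O)C(C)=C(OC)C(C)(C)C2=O)cc1` gives 1.9 ug/mL, which places compound 2 level with compound 1. Compound 3 `COC1=C(C)C(=O)/C(=C(O)/C=C/c2cccs2)C(=O)C1(C)C` is not yet measured. It has thiophen-2-yl in place of 4-ethylphenyl on a double-bonded chain carbon bound to a double-bonded chain carbon. Among the measured compounds shown here, only one measured step bears on this change, and it does so indirectly: no change at the digits printed from compound 1 to compound 2 (within the scatter). That step exchanges a group on the aromatic ring, whereas the step to compound 3 replaces the whole ring, and no measurement covers such a replacement. With so little evidence, no direction is favoured in this assay, and no shift beyond the scatter is expected. The estimated change is a 1.1-fold higher number from compound 2 to compound 3 (0.02 log units; within the scatter). For compound 3 the estimate is 2 ug/mL, with an expected range of 0.8 ug/mL to 5 ug/mL.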

Compound 3, concentration for half-maximal effect: 3.4 ug/mL
Compound 3: middle estimate off by 1.7-fold (0.23 log units), on the low side; the range from low to high includes it.
By their numbers in this assay, from the lowest: compounds 1, 2 and 3 (each within the scatter of the next).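

In this assay, thiophen-2-yl in place of 4-ethylphenyl gives a 1.8-fold higher number from compound 2 to compound 3 (0.25 log units; within the scatter) and thiophen-2-yl in place of 4-bromophenyl gives a 1.8-fold higher number from compound 1 to compound 3 (0.25 log units; within the scatter). The earlier compounds shown here exchanged only a group on the six-membered aromatic ring, whereas here a five-membered aromatic ring with 1 hetero atom replaces that whole ring on a double-bonded chain carbon bound to a double-bonded chain carbon, and both steps stay within the scatter. No supporting data explain this result.

On these data alone, whether the read-out holds with an amine or a carboxylic acid on the aromatic ring, or with a butyl chain replacing the ring, stays open. The shared core is the same in all three compounds, so the compounds shown say nothing about changes there.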